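Plasma half-life in the isosorbide diester series: compound 3

The source may report more compounds than this note shows. Statements on the series, on what has been measured and on what is new or still open speak of the compounds shown alone.

Among the measured compounds shown here, compound 2 `CC(=O)Oc1ccccc1C(=O)O[C@H]1CO[C@H]2[C@@H]1OC[C@H]2OC(=O)c1cccc(C)c1` gives 0.165 h in an ADME assay on a cell-free system (plasma, Homo sapiens) for metabolic stability, with Plasma (Rattus norvegicus) as the target, read by HPLC, at pH 7.4 (on this read-out higher numbers stand for a longer-lived compound and lower numbers for a shorter-lived compound), the higher of the two numbers so far; compound 1 `CC(=O)Oc1ccccc1C(=O)O[C@H]1CO[C@H]2[C@@H]1OC[C@H]2OC(=O)c1ccc(O)cc1` gives 0.0198 h, the gap being an 8.3-fold higher number from compound 1 to compound 2 (0.92 log units; beyond the scatter). Compound 3 `CC(=O)Oc1ccccc1C(=O)O[C@H]1CO[C@H]2[C@@H]1OC[C@H]2O[N+](=O)[O-]` differs from compound 2 by nitro in place of (3-methylphenyl)carbonyl on an oxygen on a saturated carbon. For the measured compounds named here, no measured step touches this exchange: the only step known concerns 4-hydroxyphenyl against 3-methylphenyl, and it was of modest size. For compound 3 the expected step is therefore a 1.1-fold lower number from compound 2 to compound 3 (0.04 log units; within the scatter), not beyond the scatter, with a wide margin. Compound 3 is estimated at 0.15 h (range 0.03 h to 0.8 h).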

Compound 3, half-life: 0.0144 h
Compound 3: middle estimate off by 10-fold (1.02 log units), on the high side; the measured number lies below the stated range.
By their numbers in this assay, from the lowest: compounds 3 and 1 (each within the scatter of the next); then compound 2.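

In this assay, the group on an oxygen on a saturated carbon clearly matters: nitro in place of (3-methylphenyl)carbonyl gives a large step (an 11-fold lower number from compound 2 to compound 3 (1.06 log units; beyond the scatter)). Nitro in place of (4-hydroxyphenyl)carbonyl gives a step within the scatter (a 1.4-fold lower number from compound 1 to compound 3 (0.14 log units; within the scatter)), so of these three compounds only compound 2 stands apart. Nothing at hand bears on the cause of either step. Still open, going by these compounds, is whether the standing of compound 2 belongs to the 3-methylphenyl group alone, and how an amine on this oxygen-bearing carbon would read in place of nitrooxy.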